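A few compounds are considered here, and "the series" means these few. Any claim that something is new, unique, unknown or untested is made for them only; others in the source may bear on it.

Compound 1 `CCC1CCc2c(sc(NC(=O)Nc3ccc(Cl)cc3)c2C(N)=O)C1`: > 25000 nM
Compound 2 `CN1CCc2c(sc(NC(=O)Nc3ccc(Cl)cc3)c2C(N)=O)C1`: 4700 nM

In a functional assay (strain AB) with Danio rerio as the target, read by microscopy, with a stated time of 1 h (a lower number here means that less compound is needed, a higher number that more compound is needed for the effect), compound 1 reaches only the limit of the assay, > 25000 nM, which is not a number. Within the data shown here, compound 2 gives the one actual number here, 4700 nM, and so it is the only fixed point on which to build. Compound 3 `CC(C)(C)OC(=O)CCCN1CCc2c(sc(NC(=O)Nc3ccc(Cl)cc3)c2C(N)=O)C1` differs from compound 2 in a single place: 2-(tert-butoxycarbonyl)ethyl in place of hydrogen on a saturated chain carbon bound to an amine nitrogen in a ring. No change of this kind has yet been measured, so the step from compound 2 to compound 3 is expected to be small, likely within the ordinary scatter, at an estimated 1.3-fold higher number from compound 2 to compound 3 (0.11 log units; within the scatter). Compound 3 is thus estimated at 6000 nM, with a range from 1500 nM to 25000 nM.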

Compound 3, half-maximal effective concentration: 560 nM
Compound 3: the middle estimate sits 11-fold (1.03 log units) above what was measured; the measured number lies below the stated range.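

In this assay the change from methyl to 3-(tert-butoxycarbonyl)propyl gives an 8.4-fold lower number from compound 2 to compound 3 (0.92 log units; beyond the scatter) and so less compound is needed for the effect. This position therefore accepts a much larger group than methyl, and the step lies beyond the scatter rather than leaving the number unchanged. Nothing among the data shown explains why the number falls. Still open, on these data alone, is whether the tert-butoxycarbonyl end or the chain alone matters: a carboxylic acid at the chain end, or a plain butyl chain, would separate the two.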